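The compounds below may be only part of what the source reports. "The series", "measured", "known", "first", "only" and "open" are said of these compounds alone.

Compound 2 `CC1=C(N2CC2)C(=O)C(Cc2ccccc2)=C(N2CC2)C1=O` gives 4.85 in a functional assay on L1210 cells (Mus musculus), with a stated time of 12 days (a higher number here means a more potent compound, by a factor of ten per unit of this negative logarithm, a lower number a less potent compound), the lowest of the three numbers measured; compound 3 `CCCC1=C(N2CC2)C(=O)C(CCC)=C(N2CC2)C1=O` gives 4.92, which lies within the scatter of compound 2, while compound 1 `CCCC1=C(N2CC2)C(=O)C(C(COC(N)=O)OC)=C(N2CC2)C1=O` gives 5.63, beyond the scatter above it. Compound 4 `CC1=C(N2CC2)C(=O)C(C2CCCCC2)=C(N2CC2)C1=O` differs from compound 2 in one place: cyclohexyl in place of benzyl on a double-bonded ring carbon. For the measured compounds named here, the only measured step at this position is a number 0.71 log units lower from compound 1 to compound 3 (beyond the scatter), and it involves neither a benzyl nor a cyclohexyl group, so it bears on this change only loosely. Going by the values given here, no measured pair swaps an aromatic ring for a saturated one, so nothing beyond the scatter is expected, and the step from compound 2 to compound 4 is estimated as a number 0.05 log units higher from compound 2 to compound 4 (within the scatter). Compound 4 is therefore expected to give about 4.9, between 4.4 and 5.4.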

Compound 4, logarithm of the reciprocal of the active concentration, log(1/C): 5.82
Beside the measured number, compound 4's estimate is 0.92 log units below it; measured number above the stated range.
By their numbers in this assay, from the lowest: compounds 2 and 3 (each within the scatter of the next); then compounds 1 and 4 (each within the scatter of the next).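

In this assay, this double-bonded ring carbon proves sensitive to a change between two carbon-only rings: cyclohexyl in place of benzyl gives a number 0.97 log units higher from compound 2 to compound 4 (beyond the scatter). The earlier step at this position, a number 0.71 log units lower from compound 1 to compound 3 (beyond the scatter), involved a group containing nitrogen and oxygen, whereas neither group here has any hydrogen-bond donors or acceptors. No available evidence accounts for the difference between benzyl and cyclohexyl.

On these data alone, it remains open whether the step follows from the saturated ring or from the ring's direct attachment, which a phenyl or cyclohexylmethyl group at this place could separate.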